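The source may hold more compounds than are shown below. What is called first, only, known or untested is meant among the compounds shown, and "the series" means these compounds.

Compound 1 `CCCNC(=O)C1CCN(C(=O)c2cc3sc(C(=O)c4ccccc4)cc3n2Cc2ccc(OC)cc2)CC1` gives > 100000 nM (a limit)
Compound 2 `CCCNCc1cc2c(cc(C(=O)N3CCC(C(=O)NCCC)CC3)n2Cc2ccc(OC)cc2)s1` gives > 100000 nM (a limit)

In an ADME assay on HEK-293T cells (Homo sapiens) for cytotoxicity, read by luminescence, with a stated time of 24 h (a higher number here means that more compound is tolerated, a lower number that less compound is tolerated), compound 2 stands at > 100000 nM as a limit of the assay and not as a number. Compound 1 holds the same place, with > 100000 nM as its own limit. The record so far therefore comes down to the limit of > 100000 nM in this assay, at which 2 of the 2 values shown sit, and nothing finer.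

Compound 3 `CCCNC(=O)C1CCN(C(=O)c2cc3sc(CNCc4ccccc4)cc3n2Cc2ccc(OC)cc2)CC1` is the next case. It differs from compound 2 by phenyl in place of ethyl on a saturated chain carbon bound to an amine nitrogen and has phenyl in place of ethyl on a saturated chain carbon bound to an amine nitrogen, which turns propylamino into benzylamino.

Within the data shown here, only one measured step bears on this change, namely a step that the two limits leave unreadable from compound 1 to compound 2 with (propylamino)methyl in place of benzoyl on an aromatic carbon. That step from compound 1 to compound 2 has no size to carry over, so no step beyond the usual scatter is expected in this assay for the new change. The expected step is a number no higher from compound 2 to compound 3 (the limit leaves the size open) as an estimate, and another limit is quite possible. For compound 3 the estimated value is 100000 nM with an expected range of 30000 nM to 300000 nM as the likely span.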

Compound 3, half-maximal cytotoxic concentration: 46800 nM
Beside the measured number, compound 3's estimate is 2.1-fold (0.33 log units) above it, within the range that was stated.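

In this assay, compound 3 is the first of these compounds to give a real number rather than a limit, so changes at this position can now be sized, though only from one side. Phenyl in place of ethyl on a saturated chain carbon bound to an amine nitrogen, which turns propylamino into benzylamino, gives an at least 2.1-fold lower number from compound 2 to compound 3 (0.32 log units; beyond the scatter), and exchanging the benzoyl group for a (benzylamino)methyl group gives an at least 2.1-fold lower number from compound 1 to compound 3 (0.32 log units; beyond the scatter). Both sizes are minimum sizes and the step between the two earlier compounds cannot be read, because those compounds sit at the top of what the assay reports: the limit of > 100000 nM in this assay, at which 2 of the 3 values shown sit.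

The compounds shown cannot tell whether the lower number depends on the aromatic ring of the benzyl group or would also appear with a cyclohexylmethyl group or a longer chain on the amine nitrogen. They also leave open how a fluorine, a methoxy group or a carboxylic acid on that phenyl ring would move the number in this assay.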